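One aromatic ring swapped on a saturated chain

The compounds below may be only part of what the source reports. "The series", "measured", "known", "first", "only" and "open" are said of these compounds alone.

Measured in an ADME assay on liver for metabolic stability, with Liver microsome (Homo sapiens) as the target, read by LC-MS, using microsomes; on this read-out higher numbers stand for fast clearance and lower numbers for slow clearance:
- Compound 1 `O=C(NCc1cc(Cl)ccc1-n1cnnn1)[C@@H]1C[C@@H]2C[C@@H]2N1C(=O)[C@H](O)Cn1cccn1`: < 12 mL.min-1.g-1 (a limit)
- Compound 2 `CCCC[C@@H](O)C(=O)N1C[C@H]2C[C@H]2[C@H]1C(=O)NCc1cc(Cl)ccc1-n1cnnn1`: 32 mL.min-1.g-1

Compound 1 has no exact number in this assay: its reading, < 12 mL.min-1.g-1, is a limit of the assay. Compound 1 therefore stands at the limit of < 12 mL.min-1.g-1 in this assay, at which 1 of the 2 values shown sits. Compound 2 gives a true number, 32 mL.min-1.g-1, but it differs from compound 1 in more than one place, so the two do not form a clean comparison.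

Compound 3 `O=C(NCc1cc(Cl)ccc1-n1cnnn1)[C@@H]1C[C@@H]2C[C@@H]2N1C(=O)[C@H](O)Cc1ccccn1` has not yet been measured. It keeps the core of compound 1 and changes one group: pyridin-2-yl in place of 1H-pyrazol-1-yl on a saturated chain carbon, two bonds along the chain from a carbonyl carbon and an oxygen on a saturated carbon. The change lies on a saturated chain carbon, two bonds along the chain from a carbonyl carbon and an oxygen on a saturated carbon.

Among the measured compounds shown here, no measured pair shows this swap, so any forecast is loose. A small rise in this assay is expected, perhaps none beyond the usual scatter, and the estimated step is an at least 1.2-fold higher number from compound 1 to compound 3 (0.09 log units; that floor lies within the scatter). For the measured compounds named here, the only true number available, compound 2 at 32 mL.min-1.g-1, serves as a rough upper guide. For compound 3 the expected value is 15 mL.min-1.g-1, with an estimated range from 8 mL.min-1.g-1 to 30 mL.min-1.g-1.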

Compound 3, intrinsic clearance in microsomes: 17 mL.min-1.g-1
Compound 3: middle estimate off by 1.1-fold (0.05 log units), on the low side; low and high end bracket the measured number.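

Among the compounds shown here, compound 3 gives the first true number in this assay for a compound that keeps the core of compound 1, so this saturated chain carbon now has a reading that is not a limit. Placing pyridin-2-yl there in place of 1H-pyrazol-1-yl, a six-membered aromatic ring for a five-membered one, gives an at least 1.4-fold higher number from compound 1 to compound 3 (0.15 log units; that floor lies within the scatter), so the swap shows no firm change so far, although the ring can be exchanged without the number reaching that of compound 2, which differs in more than one place. The step can be read only as a floor, and not as an exact size, because compound 1 gives a limit and not a number: the limit of < 12 mL.min-1.g-1 in this assay, at which 1 of the 3 values shown sits.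

The compounds shown leave open how far compound 1 really lies from compound 3, and so whether the swap changes the clearance at all or by more than the floor suggests. They also leave open how this chain carbon would read with a different group on it, such as pyridin-3-yl, a plain phenyl ring, an amine or a carboxylic acid.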